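This account rests on a few compounds, and the source may have more. Where it says the series, first, only, none or still open, it means among the compounds named here.

Compound 1 `CN1CCN(c2ccc(C3=NNC(c4ccc(N(C)C)cc4)C3)cc2)CC1`: 11.4%
Compound 2 `CN(C)c1ccc(C2CC(c3ccc(-n4cncn4)cc3)=NN2)cc1`: 7%
Compound 3 `CN(C)c1ccc(C2CC(c3ccc(-n4ccnc4)cc3)=NN2)cc1`: 7.6%

In a functional assay on MDA-MB-231 cells (Homo sapiens) for inhibition, read by sulforhodamine B assay, tested at 10 uM (a lower number here means less inhibition, a higher number more inhibition at the concentration tested (going by the name of the read-out)), compound 3 stands second highest of the three numbers, with all three close together: the step of a number 0.6 percentage points higher from compound 2 to compound 3 (within the scatter) and the step of a number 3.8 percentage points lower from compound 1 to compound 3 (within the scatter) both lie within the scatter, so no ordering among them can be claimed. Compound 4 `CC(=O)N1N=C(c2ccc(-n3ccnc3)cc2)CC1c1ccc(N(C)C)cc1` differs from compound 3 by acetyl in place of hydrogen on an amine nitrogen in a ring. Among the compounds with values here, none of the measured steps bears on this change: each of them exchanges the group on an aromatic carbon, and none touches the ring nitrogen. Within the data shown here, with no guiding step, the number for compound 4 is expected to stay near that of compound 3, with a step of a number 0.4 percentage points higher from compound 3 to compound 4 (within the scatter) that is not expected to exceed the scatter. Compound 4 is estimated at 8%, within a range of 0% to 25%.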

Compound 4, a percentage reported as inhibition, at one concentration (the size of the read-out at that concentration, not a potency): 5%
For compound 4 the middle estimate is 3 percentage points above the measured one, within the range that was stated.
By their numbers in this assay, from the lowest: compounds 4, 2, 3 and 1 (each within the scatter of the next).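

In this assay, acetyl in place of hydrogen on the amine nitrogen in the ring gives a number 2.6 percentage points lower from compound 3 to compound 4 (within the scatter). Within the data shown here, this is the first reading at this nitrogen, which the earlier steps left untouched, and the acetyl brings no change that can be told from the scatter. Nothing measured here offers a reason for this result.

From the compounds shown here alone, whether a propanoyl, a benzoyl or a plain methyl on this nitrogen would read differently stays open. So does whether acetyl would read the same with 4-methylpiperazin-1-yl or 1H-1,2,4-triazol-1-yl on the aromatic carbon.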